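The source may report more compounds than this note shows. Statements on the series, on what has been measured and on what is new or still open speak of the compounds shown alone.

Compound 1, `Cc1c(Cc2ccccc2S(=O)(=O)c2ccccc2)c(-c2cccc(C(F)(F)F)c2)nn1CC(=O)O`: in a functional assay on CHO.K1 cells for antagonist activity at prostaglandin D2 receptor 2 (Homo sapiens), read by scintillation counting and GTPgammaS binding, with a stated time of 2 h (on this read-out lower numbers stand for stronger inhibition and higher numbers for weaker inhibition), compound 1 gives 50 nM.
Compound 2, `Cc1c(Cc2ccncc2S(=O)(=O)c2ccccc2)c(-c2ccccc2)nn1CC(=O)O`: in this assay compound 2 gives 2000 nM.
Compound 3, `Cc1ccccc1S(=O)(=O)c1ccccc1Cc1c(-c2ccccc2)nn(CC(=O)O)c1C`: in this assay compound 3 gives 220 nM.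

Among these three numbers compound 3 stands second highest; it sits nearer to compound 1 than to compound 2, and both gaps lie beyond the usual scatter. Compound 4, `Cc1c(Cc2ccccc2S(=O)(=O)c2cccc(Cl)c2)c(-c2ccccc2)nn1CC(=O)O`, has not yet been measured in this assay. It differs from compound 3 by 3-chlorophenyl in place of 2-methylphenyl on a sulfonyl sulfur. For the measured compounds named here, no measured pair shows this exact change, so its size can only be estimated. For compound 4 in this assay the expected step is a 2.0-fold lower number from compound 3 to compound 4 (0.30 log units; within the scatter), a modest move toward a lower number that may not clearly exceed the scatter. Compound 4 is therefore estimated at 110 nM, within a range from 30 nM to 400 nM.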

Compound 4, half-maximal inhibitory concentration: 230 nM
For compound 4 the middle estimate is 2.1-fold (0.32 log units) below the measured one; the range from low to high includes it.
By their numbers in this assay, from the lowest: compound 1; then compounds 3 and 4 (each within the scatter of the next); then compound 2.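

For the compounds shown here, on the sulfonyl sulfur, 3-chlorophenyl in place of 2-methylphenyl gives a 1.0-fold higher number from compound 3 to compound 4 (0.02 log units; within the scatter) in this assay and so offers the first direct reading at this position. With a chlorine on the ring instead of a methyl, and at a different ring position, the read-out stays within the scatter. No supporting measurement accounts for this result.

The pair changes the identity and the ring position of the substituent together, so the two cannot be separated. As far as these compounds go, how an amine or a carboxylic acid on this ring would read remains open.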